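This account rests on a few compounds, and the source may have more. Where it says the series, first, only, none or still open, it means among the compounds named here.

Measured so far:
compound 1 `COc1cc(C(=O)/C=C/c2ccc(N(C)C)cc2)cc(OC)c1OC`: 75000 nM
compound 2 `COc1cc(OC)c(OC)cc1/C=C/C(=O)c1cc(OC)c(OC)c(OC)c1`: 18600 nM
compound 3 `COc1cccc(/C=C/C(=O)c2cc(OC)c(OC)c(OC)c2)c1O`: 13000 nM

All three were read in a functional assay on COLO 205 cells (Homo sapiens) for inhibition, read by MTT assay, with a stated time of 48 h; on this read-out lower numbers stand for stronger inhibition and higher numbers for weaker inhibition. Compound 1 stands highest of the three, and the other two lie lower by more than the scatter. Next in line is compound 4 `COc1cc(C(=O)/C=C/c2ccc(C)cc2)cc(OC)c1OC`, with the change methyl in place of dimethylamino on an aromatic carbon. Among the compounds with values here, no measured pair shows this change alone, so the expectation is indirect. Compound 2 at 18600 nM and compound 3 at 13000 nM also lack dimethylamino. The estimated step is a 3.0-fold lower number from compound 1 to compound 4 (0.48 log units; beyond the scatter), expected towards stronger inhibition and beyond the scatter. Compound 4 is estimated at 25000 nM, with an expected range of 9000 nM to 70000 nM.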

Compound 4, half-maximal inhibitory concentration: 41500 nM
Compound 4: the middle estimate sits 1.7-fold (0.22 log units) below what was measured; measured number inside the range.
By their numbers in this assay, from the lowest: compounds 3 and 2 (each within the scatter of the next); then compounds 4 and 1 (each within the scatter of the next).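

In this assay, within the data shown here, methyl in place of dimethylamino on an aromatic carbon, para to a large group, gives a 1.8-fold lower number from compound 1 to compound 4 (0.26 log units; within the scatter) and is the only one-place comparison so far. At this position the two groups are therefore not separated by this read-out, and the standing of compound 1 among the three earlier compounds is not traced to dimethylamino by this step. No measurement at hand bears on the reason for this result.

On these data alone, whether a carboxylic acid or a longer chain at the same position would give a step beyond the scatter remains open.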